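Ester to acid step from compound 3 to compound 4

This account rests on a few compounds, and the source may have more. Where it says the series, first, only, none or still open, it means among the compounds named here.

Compound 3 `CCOC(=O)C(=O)CC(=O)/C=C/c1cn(CC(=O)N2CCOCC2)c2ccccc12` is the ethyl ester of the pair. In an assay on isolated protein for inhibition of DNA nucleotidylexotransferase (Homo sapiens), read by scintillation counting, with a stated time of 10 min (on this read-out higher numbers stand for weaker inhibition and lower numbers for stronger inhibition), compound 3 gives > 40 uM, which is a limit of the assay and not a number. The two related esters stand no differently. Compound 1 `C/C=C/n1cc(/C=C/C(=O)CC(=O)C(=O)OCC)c2ccccc21` in this assay gives > 40 uM, again a limit. Compound 2 `C/C=C/Cn1cc(/C=C/C(=O)CC(=O)C(=O)OCC)c2ccccc21` in this assay gives > 40 uM, also a limit. All three values sit at the limit of > 40 uM in this assay, at which 3 of the 3 values shown sit, so the changes on the aromatic nitrogen among them leave a step that the two limits leave unreadable from compound 1 to compound 2, a step that the two limits leave unreadable from compound 1 to compound 3 and a step that the two limits leave unreadable from compound 2 to compound 3 unreadable in size. None of these steps touches the ester, and none bears on the change to compound 4 `O=C(/C=C/c1cn(CC(=O)N2CCOCC2)c2ccccc12)CC(=O)C(=O)O`. Compound 4 differs from compound 3 by hydrogen in place of ethyl on an oxygen next to a carbonyl group. With compound 3 itself at a limit in this assay, the expected step of an at least 2.6-fold lower number from compound 3 to compound 4 (0.42 log units; beyond the scatter) rests on the structural change alone, and a further limit remains a real possibility. Compound 4 is expected in this assay at about 15 uM, within 2 uM to 60 uM.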

Compound 4, concentration for 50% inhibition: 24 uM
Beside the measured number, compound 4's estimate is 1.6-fold (0.20 log units) below it; the measured number falls inside the stated range.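

In this assay, compound 4, with its carboxy group, is the only compound shown that gives a number rather than a limit, and this yields the one step in the series with a readable floor: an at least 1.6-fold lower number from compound 3 to compound 4 (0.22 log units; that floor lies within the scatter). That floor does not by itself separate the ethoxycarbonyl to carboxy change from the scatter, so a real gain is possible but not established. The three ethyl esters stay at a limit, and the steps among them cannot be read: the limit of > 40 uM in this assay, at which 3 of the 4 values shown sit.

As far as these compounds go, whether the carboxy group also gives a number with prop-1-en-1-yl or but-2-en-1-yl on the aromatic nitrogen stays open. Also open, from the compounds shown here alone, is how a methyl ester or a primary amide would read in place of the carboxy group of compound 4.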